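Cyclopropyl for trifluoromethylphenyl at the thioether of compound 3

The source may report more compounds than this note shows. Statements on the series, on what has been measured and on what is new or still open speak of the compounds shown alone.

The three measured compounds share one core and differ only at one aromatic carbon. Compound 1 `Cc1cc(N2CC[C@@H](C)[C@@H](N(C)c3ncnc4[nH]ccc34)C2)n2ncnc2n1` bears hydrogen there, and in a functional assay on HGC-27 cells (Homo sapiens) for inhibition, read by MTT assay, with a stated time of 72 h (on this read-out lower numbers stand for stronger inhibition and higher numbers for weaker inhibition), compound 1 gives 11300 nM. Compound 2 `CCCSc1nc2nc(C)cc(N3CC[C@@H](C)[C@@H](N(C)c4ncnc5[nH]ccc45)C3)n2n1` carries propylsulfanyl at that carbon, and compound 2 gives 20900 nM. Compound 3 `Cc1cc(N2CC[C@@H](C)[C@@H](N(C)c3ncnc4[nH]ccc34)C2)n2nc(SCc3ccc(C(F)(F)F)cc3)nc2n1` carries (4-(trifluoromethyl)benzyl)sulfanyl, and compound 3 gives 9540 nM. Within the data shown here, compound 3 has the lowest number of the three: one step is a 1.2-fold lower number from compound 1 to compound 3 (0.07 log units; within the scatter), and the other is a 2.2-fold lower number from compound 2 to compound 3 (0.34 log units; beyond the scatter), the only step here that reaches beyond the scatter. The step of a 1.8-fold higher number from compound 1 to compound 2 (0.27 log units; within the scatter) stays within it.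

Compound 4 `Cc1cc(N2CC[C@@H](C)[C@@H](N(C)c3ncnc4[nH]ccc34)C2)n2nc(SCC3CC3)nc2n1` is the next step from compound 3: cyclopropyl in place of 4-(trifluoromethyl)phenyl on a saturated chain carbon bound to a sulfur. Among the measured compounds shown here, the step bearing on it is the one from compound 2 to compound 3, where 4-(trifluoromethyl)phenyl replacing ethyl on the saturated chain carbon bound to sulfur gave a modest lowering. Removing that aryl again and setting a small carbon ring in its place is expected to hand back part of that gain, leaving compound 4 nearer compound 2 than compound 3 in this assay. Compound 4 is therefore estimated at 16000 nM with a range of 7000 nM to 36000 nM, meaning an expected step of a 1.7-fold higher number from compound 3 to compound 4 (0.22 log units; within the scatter).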

Compound 4, half-maximal inhibitory concentration: 21400 nM
Beside the measured number, compound 4's estimate is 1.3-fold (0.13 log units) below it; the range from low to high includes it.
By their numbers in this assay, from the lowest: compounds 3, 1, 2 and 4 (each within the scatter of the next, the first and the last beyond it).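

In this assay the change from 4-(trifluoromethyl)phenyl to cyclopropyl on the saturated chain carbon bound to a sulfur gives a 2.2-fold higher number from compound 3 to compound 4 (0.35 log units; beyond the scatter) and, set against the ethyl end of the propylsulfanyl group, cyclopropyl gives a 1.0-fold higher number from compound 2 to compound 4 (0.01 log units; within the scatter) so the two non-aromatic ends cannot be told apart, and compound 3 now differs beyond the scatter from both. This separation holds only among the three thioethers, and compound 1 goes against any wider reading: the step to the aryl thioether is a 1.2-fold lower number from compound 1 to compound 3 (0.07 log units; within the scatter) and the step to the cyclopropyl thioether is a 1.9-fold higher number from compound 1 to compound 4 (0.28 log units; within the scatter) so neither thioether can be told apart from the hydrogen compound. No supporting data are available to explain these differences.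

Still open, as far as these compounds go, is whether the difference belongs to the aromatic ring or to its trifluoromethyl, a question that an unsubstituted phenyl or a 4-methoxyphenyl on the same saturated chain carbon bound to a sulfur would address. Also open, from the compounds shown here alone, is how a longer chain, or a chain ending in an amine or a carboxylic acid, would read at this position.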